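The compounds below may be only part of what the source reports. "The series", "measured", "known", "first", "only" and "open" are said of these compounds alone.

Among the three compounds whose numbers are in hand, only one gives a true value in an assay on HEK-293T cells for inhibition of diacylglycerol lipase-alpha (Homo sapiens), read by colorimetric assay; on this read-out lower numbers stand for stronger inhibition and higher numbers for weaker inhibition. Compound 1 `O=C(CCCCCc1ccccc1)c1nc2ccc([N+](=O)[O-])cc2o1` gives 87.1 nM in this assay. Compound 2 `Cn1nnc(C(=O)CCCCCCc2ccccc2)n1`, built on a different core, reaches only the limit of this assay, > 10000 nM. Compound 3 `O=C(CCCCCCc1ccccc1)c1nnn(-c2ccco2)n1` likewise stands at the limit of this assay, > 10000 nM. Among the measured compounds shown here, the single step measured between compounds of one core, a step that the two limits leave unreadable from compound 2 to compound 3, cannot be sized because both of its ends rest at the limit of > 10000 nM in this assay, at which 2 of the 3 values shown sit. Compound 3 therefore stands at the weak end of what the numbers show, with no value of its own.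

Compound 4 `O=C(CCCCCCc1ccccc1)c1nnn(-c2cccs2)n1` differs from compound 3 by thiophen-2-yl in place of furan-2-yl on an aromatic nitrogen. For the measured compounds named here, no measured step touches this exchange of one five-membered heteroaryl for another on the same ring nitrogen, and the one step on the shared core of compound 3 gives no readable size. The expectation for compound 4 can therefore rest only on compound 3 sitting at > 10000 nM, so the step from compound 3 to compound 4 is expected to be a step that the limit leaves unreadable from compound 3 to compound 4, no change beyond the scatter. Compound 4 is thus estimated to give 12000 nM in this assay, within a range from 3000 nM to 40000 nM.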

Compound 4, half-maximal inhibitory concentration: > 10000 nM
Compound 4: no number, only a limit; the forecaster's own chance of this, stated with the estimate: 80%; the middle value is on the limit's open side.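

Compound 4 also gives only a limit, so no step among compound 2, compound 3 and compound 4 can be read, because all three rest at the same point: the limit of > 10000 nM in this assay, at which 3 of the 4 values shown sit.

The compounds shown leave open how strongly these three inhibit the enzyme, and whether the group on the aromatic nitrogen matters on this shared core.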